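Replacing the piperazin-1-yl group of compound 1

A few compounds are considered here, and "the series" means these few. Any claim that something is new, unique, unknown or untested is made for them only; others in the source may bear on it.

Within the data shown here, in an ADME assay on microsomes from liver (Homo sapiens) for metabolic stability, read by LC-MS, using NADPH, with a stated time of 60 min, tested at 0.1 uM (a higher number here means that more of the compound is left, a lower number that less of the compound is left), compound 1 (`Fc1ccc(Nc2cc3[nH]c(Nc4cc(N5CCNCC5)ccn4)nc3cn2)cc1C(F)(F)F`) gives 98% and stands highest of the two numbers so far. Compound 2 (`C[C@@H]1CN(c2ccc(Nc3nc4cnc(Nc5ccc(F)c(F)c5)cc4[nH]3)nc2)C[C@H](C)N1`) lies lower at 63% by a gap beyond the scatter. Compound 3 (`O=C(c1ccnc(Nc2nc3cnc(Nc4ccc(F)c(C(F)(F)F)c4)cc3[nH]2)c1)N1CCN(C2CC2)CC1`) carries (4-cyclopropylpiperazin-1-yl)carbonyl in place of piperazin-1-yl on an aromatic carbon. Among the measured compounds shown here, no measured step shows what this change does. With compound 1 at 98% there is little room upward. A moderate fall beyond the scatter is therefore expected, estimated as a number 18 percentage points lower from compound 1 to compound 3 (beyond the scatter) in this assay for this change. Compound 3 is estimated at 80% within an expected range from 58% to 98% in this test.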

Compound 3, percent of the compound remaining: 77%
Beside the measured number, compound 3's estimate is 3 percentage points above it; the measured number falls inside the stated range.
By their numbers in this assay, from the lowest: compound 2; then compound 3; then compound 1.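

In this assay, the place opposite the ring nitrogen now has its first measured step: (4-cyclopropylpiperazin-1-yl)carbonyl in place of piperazin-1-yl gives a number 21 percentage points lower from compound 1 to compound 3 (beyond the scatter), so this change does register here. Even so, compound 3 stands at 77%, so most of the compound is still left. Nothing measured here explains the step.

The compounds shown leave open whether the carbonyl or the cyclopropyl carries the step. On these data alone, how a morpholine at this place would read also remains open.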